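Aryl carboxylic acid variation in a mGlu2 modulator series

The source may report more compounds than this note shows. Statements on the series, on what has been measured and on what is new or still open speak of the compounds shown alone.

The shared core of compound 1 `Cc1c(OCCCCOc2ccc(C(=O)O)cc2Cl)ccc(C(=O)CC2CCCC2)c1O` carries the aryl carboxylic acid at the end of the linker. In an assay on HEK293 cells for positive allosteric modulation of metabotropic glutamate receptor 2 (Rattus norvegicus), read by thallium flux, with a stated time of 2.5 min (on this read-out higher numbers stand for an effect only at larger amounts of compound and lower numbers for an effect already at smaller amounts), compound 1 gives 237 nM. Compound 3 `Cc1c(OCCCCOc2ccccc2C(=O)O)ccc(C(=O)CC(C)C)c1O` in this assay gives 415 nM. Of the two numbers compound 1 is the lower, yet the gap to compound 3 lies within the usual scatter, so the two cannot be told apart. Compound 2 `Cc1c(OCCCCOc2ccc(C(=O)O)cc2)ccc(C(=O)CC2CCCC2)c1C` in this assay gives "not determined" (no result reported), that is, no result is reported for it.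

Compound 4 `Cc1c(OCCCCOc2ccc(F)c(C(=O)O)c2)ccc(C(=O)CC2CCCC2)c1O` differs from compound 1 in one place: 3-carboxy-4-fluorophenyl in place of 4-carboxy-2-chlorophenyl on an oxygen on a saturated carbon. Both the carboxy position and the halogen change at once, without a measured single step to lean on. Since compound 1 at 237 nM and compound 3 at 415 nM sit close despite differing acids, the step from compound 1 to compound 4 is expected to be small, as a 1.7-fold higher number from compound 1 to compound 4 (0.23 log units; within the scatter), towards a somewhat higher number, and possibly within the scatter. For compound 4 in this assay a value of about 400 nM is estimated, with a range from 150 nM to 1200 nM.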

Compound 4, half-maximal effective concentration: 699 nM
For compound 4 the middle estimate is 1.7-fold (0.24 log units) below the measured one; the range from low to high includes it.
By their numbers in this assay, from the lowest: compounds 1, 3 and 4 (each within the scatter of the next, the first and the last beyond it).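

In this assay, for the compounds shown here, the change from 4-carboxy-2-chlorophenyl to 3-carboxy-4-fluorophenyl on an oxygen on a saturated carbon gives the first readable step, with a 2.9-fold higher number from compound 1 to compound 4 (0.47 log units; beyond the scatter) as a modest loss. The aryl acid at this end of the linker therefore matters: with the rest of the core of compound 1 held fixed, this exchange alone moves the number beyond the scatter. Nothing at hand accounts for the shift.

The carboxy position and the halogen change together here, so the step cannot be divided between them. On these data alone, it remains open how the number would respond to a bromine or a methyl in place of the halogen, or to a tetrazole in place of the carboxylic acid.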